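The source may report more compounds than this note shows. Statements on the series, on what has been measured and on what is new or still open speak of the compounds shown alone.

Measured so far:
compound 1 `CC#CC(CC(=O)O)c1ccc(OCc2ccc3nc(-c4ccccc4)cn3c2)cc1` — 979 nM
compound 2 `CC#CC(CC(=O)O)c1ccc(OCc2ccn3cc(-c4cccc(C)c4)nc3c2)cc1` — 1510 nM

In an assay on isolated protein for agonist activity at Free fatty acid receptor 1 (Homo sapiens) (on this read-out lower numbers stand for an effect already at smaller amounts and higher numbers for an effect only at larger amounts of compound), compound 1 gives 979 nM, the lowest of the two numbers shown. Compound 2 in this assay gives 1510 nM; the gap between the two lies within the usual scatter of repeated measurements, so no order can be read from it. For the measured compounds named here, compound 2 carries the 3-methylphenyl group on a differently arranged core, and no single-point step connects it to compound 1. Compound 3 `CC#CC(CC(=O)O)c1ccc(OCc2ccc3nc(-c4cccc(C)c4)cn3c2)cc1` is the unmeasured member; relative to compound 1 the change is methyl in place of hydrogen on an aromatic carbon. Going by the values given here, no measured step for this change exists. Since compound 2 gives 1510 nM with the same 3-methylphenyl group and sits within the scatter of compound 1, the expected step is a 1.0-fold higher number from compound 1 to compound 3 (0.01 log units; within the scatter), small and without a clear direction. Compound 3 is estimated at 1000 nM, in the range 400 nM to 2500 nM.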

Compound 3, half-maximal effective concentration: 1050 nM
Compound 3: middle estimate off by 1.1-fold (0.02 log units), on the low side; measured number inside the range.
By their numbers in this assay, from the lowest: compounds 1, 3 and 2 (each within the scatter of the next).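

In this assay, for the compounds shown here, the change from phenyl to 3-methylphenyl gives a 1.1-fold higher number from compound 1 to compound 3 (0.03 log units; within the scatter) and is the first comparison that differs in one place. On the shared core, a methyl on this aromatic carbon therefore leaves the read-out within the scatter, which the different core of compound 2 could not show. No measurement at hand bears on the reason for this result.

The compounds shown leave open whether a different group at this place, such as a methoxy, a chlorine atom, an amine or a longer chain like propyl, would move the number beyond the scatter. They also leave open whether the same methyl has a comparable effect on the core of compound 2, whose phenyl partner is not among them.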